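The source may hold more compounds than are shown below. What is called first, only, known or untested is meant among the compounds shown, and "the series" means these compounds.

Two N-formyl amides carrying two small saturated rings have been measured in an assay for inhibition of alcohol dehydrogenase (Equus caballus); on this read-out higher numbers stand for weaker inhibition and lower numbers for stronger inhibition. Compound 1 `O=CN(C1CCCC1)C1CC1` bears a cyclopentyl and a cyclopropyl group on the amide nitrogen; in this assay compound 1 gives 110000 nM. Compound 2 `O=CN(C1CCC1)C1CCC1` carries two cyclobutyl groups and in this assay compound 2 gives 7200000 nM. Of the two numbers, that of compound 1 is the lower, and the gap to compound 2 lies beyond the scatter of repeated measurements.

Compound 3 `O=CN(C1CCCC1)C1CCC1` has not yet been measured. It differs from compound 1 in one place: cyclobutyl in place of cyclopropyl on an amide-type nitrogen. Going by the values given here, since no pair of measured compounds differs in exactly this way, the size of the change can only be guessed. The number for compound 2, which carries a cyclobutyl group in both positions, is much the higher of the two, so a shift towards weaker inhibition is expected for compound 3, though a smaller one than the whole distance to compound 2. The step expected from this change is a 3.2-fold higher number from compound 1 to compound 3 (0.50 log units; beyond the scatter). The estimate for compound 3 in this assay is therefore 350000 nM, with a plausible range from 100000 nM to 1500000 nM.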

Compound 3, inhibition constant: 8600000 nM
Estimate against measurement, compound 3: 25-fold (1.39 log units) below; measured number outside the range, above it.
By their numbers in this assay, from the lowest: compound 1; then compounds 2 and 3 (each within the scatter of the next).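

Going by these compounds alone, with cyclopentyl kept as the other group on the amide-type nitrogen, putting cyclobutyl in place of cyclopropyl gives a 78-fold higher number from compound 1 to compound 3 (1.89 log units; beyond the scatter) in this assay and provides the first direct reading of this change, showing that this position responds strongly to the step from a three-membered to a four-membered ring of carbon only. Compound 3 also stands within the scatter of compound 2, which differs from it in one place by carrying cyclobutyl in place of cyclopentyl, so among the two compounds with a cyclobutyl group and this other group varied, the printed numbers do not separate. Nothing measured here explains why the step between cyclopropyl and cyclobutyl is so large.

As far as these compounds go, it remains open whether cyclopropyl itself is required for the lower number or whether an open chain such as ethyl or isopropyl on the same nitrogen would read similarly. From the compounds shown here alone, it is also open whether cyclopropyl would keep its advantage over cyclobutyl with a larger partner such as cyclohexyl, or with a partner other than cyclopentyl.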